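A few compounds are considered here, and "the series" means these few. Any claim that something is new, unique, unknown or untested is made for them only; others in the source may bear on it.

In a functional assay on K562 cells (Homo sapiens) for antiproliferative activity, read by MTT assay, with a stated time of 24 h (on this read-out lower numbers stand for stronger inhibition and higher numbers for weaker inhibition), compound 1 `COC(=O)c1scc(-c2ccc(NC(=O)c3ccc4ccccc4c3)cc2)c1OC` gives 10300 nM. Compound 2 `COC(=O)c1scc(-c2ccc(NC(=O)c3cccc(C(F)(F)F)c3)cc2)c1OC` gives 6130 nM, and for compound 3 `COC(=O)c1scc(-c2ccc(NC(=O)c3ccc(C#N)nc3)cc2)c1OC` the entry reads "not determined" (no result reported), so no result was reported. Within the data shown here, the only measured step, a 1.7-fold lower number from compound 1 to compound 2 (0.23 log units; within the scatter), replaces naphthalen-2-yl with 3-(trifluoromethyl)phenyl on the carbonyl carbon and lies within the scatter. Compound 4 `COC(=O)c1scc(-c2ccc(NC(=O)c3ccc(C(F)(F)F)cc3)cc2)c1OC` differs from compound 1 by 4-(trifluoromethyl)phenyl in place of naphthalen-2-yl on a carbonyl carbon. Among the measured compounds shown here, that measured step is the one comparison that bears here, and because it amounted to a 1.7-fold lower number from compound 1 to compound 2 (0.23 log units; within the scatter), no shift beyond the scatter is expected for compound 4. The expected step is therefore a 1.5-fold lower number from compound 1 to compound 4 (0.17 log units; within the scatter). Compound 4 is estimated at 7000 nM, within a range from 3000 nM to 16000 nM.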

Compound 4, half-maximal inhibitory concentration: 9260 nM
The estimate for compound 4 lay 1.3-fold (0.12 log units) below the measured number, and the stated range covers the measured number.
By their numbers in this assay, from the lowest: compounds 2, 4 and 1 (each within the scatter of the next).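

The steps of a 1.1-fold lower number from compound 1 to compound 4 (0.05 log units; within the scatter) and a 1.5-fold higher number from compound 2 to compound 4 (0.18 log units; within the scatter) show that in this assay the 4-(trifluoromethyl)phenyl group on the carbonyl carbon cannot be told apart from either naphthalen-2-yl or 3-(trifluoromethyl)phenyl. Across compounds 1, 2 and 4, neither exchanging the two aromatic rings of naphthalen-2-yl for one nor changing the place of trifluoromethyl on the phenyl group gives a step beyond the scatter. No measurement available here accounts for this. From the compounds shown here alone, whether a carboxylic acid or an aliphatic amine on this carbonyl carbon would give a step beyond the scatter remains open. Compound 3 has no number, so its nitrile-bearing group cannot be compared.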